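The source may hold more compounds than are shown below. What is called first, only, known or untested is meant among the compounds shown, and "the series" means these compounds.

Measured compounds:
compound 1, `Cc1n[nH]c(-c2ncc3c(-c4ccccc4)ccnc3c2O)n1`, "not determined" (no result reported)
compound 2, `Cc1n[nH]c(-c2ncc3c(-c4ccccc4C(F)(F)F)ccnc3c2O)n1`, 4.3

In a physicochemical assay for lipophilicity, at pH 7.4 (on this read-out lower numbers stand for lower lipophilicity and higher numbers for higher lipophilicity), compound 2 gives 4.3. Going by the values given here, this is the only number in hand: compound 1 was not measured and has no result, so compound 2 stands alone, with no measured partner to place it against. Compound 3, `COc1ccccc1-c1ccnc2c(O)c(-c3nc(C)n[nH]3)ncc12`, differs from compound 2 by methoxy in place of trifluoromethyl on an aromatic carbon. Among the compounds with values here, no step between measured compounds covers this change, so the direction and size have to be set as an expectation rather than read from the series. The replacement is expected to lower the read-out in this assay by clearly more than the scatter, an estimated step of a number 1.00 log units lower from compound 2 to compound 3 (beyond the scatter). For compound 3 the value in this assay is estimated at 3.3, with a range from 2.8 to 3.8. The measurement will show whether this holds.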

Compound 3, distribution coefficient: 3.2
For compound 3 the middle estimate is 0.10 log units above the measured one; measured number inside the range.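

In this assay, going by these compounds alone, methoxy in place of trifluoromethyl on an aromatic carbon ortho to a large group gives a number 1.10 log units lower from compound 2 to compound 3 (beyond the scatter) and so supplies the first measured step. The read-out at this position thus responds to the exchange of substituent by more than the scatter, which a single number could not show. With one pair in hand, this holds for this exchange alone and sets no trend across substituents.

As far as these compounds go, how an amine or a nitrile on this aromatic carbon would stand on the same read-out stays open, as does whether a step of this size carries over to other places on the shared core. No measurement at hand speaks to why the step has this size.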